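Swapping the aromatic ring for cyclohexyl at the ester

The source may report more compounds than this note shows. Statements on the series, on what has been measured and on what is new or still open speak of the compounds shown alone.

compound 1 `CSc1ncc(C2C(C(=O)OC(C)C)=C(C)NC(C)=C2C(=O)OC(C)(C)C)n1Nc1ccccc1`: 68.2 nM
compound 2 `CSc1ncc(C2C(C(=O)OCCCc3ccccc3)=C(C)NC(C)=C2C(=O)OC(C)C)n1Nc1ccccc1`: 6.22 nM

In an assay on isolated protein (strain albino) for antagonist activity at Voltage-dependent L-type calcium channel subunit alpha-1C (Cavia porcellus) (a higher number here means a weaker inhibitor, a lower number a stronger inhibitor), compound 1 gives 68.2 nM and compound 2 gives 6.22 nM. Going by the values given here, compound 2 holds the lowest of the two numbers; its nearest neighbour is compound 1, and the single measured step, an 11-fold lower number from compound 1 to compound 2 (1.04 log units; beyond the scatter), joins them. Compound 3 `CSc1ncc(C2C(C(=O)OCC3CCCCC3)=C(C)NC(C)=C2C(=O)OC(C)C)n1Nc1ccccc1` differs from compound 2 in one place: cyclohexyl in place of phenethyl on a saturated chain carbon bound to an oxygen next to a carbonyl group. Among the compounds with values here, the only step that bears on the same oxygen is an 11-fold lower number from compound 1 to compound 2 (1.04 log units; beyond the scatter), which shows that the group on the ester oxygen can shift the number strongly. That step, however, exchanged a branched group for a longer chain ending in an aromatic ring, whereas the present change keeps a chain on that oxygen and exchanges the aromatic ring at its end for a saturated ring of the same size. Within the data shown here, no measured pair tells how an aromatic and a saturated ring compare here, so the firm ground is thin. A small step toward a higher number is expected, a 1.6-fold higher number from compound 2 to compound 3 (0.21 log units; within the scatter). For compound 3 the estimate is 10 nM, with a range from 3 nM to 35 nM.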

Compound 3, half-maximal inhibitory concentration: 56 nM
The estimate for compound 3 lay 5.6-fold (0.75 log units) below the measured number; measured number above the stated range.
By their numbers in this assay, from the lowest: compound 2; then compounds 3 and 1 (each within the scatter of the next).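

In this assay, the ring at the end of the ester group proves to matter, and cyclohexyl in place of phenethyl gives a 9.0-fold higher number from compound 2 to compound 3 (0.95 log units; beyond the scatter); at this position the saturated ring does not serve as a match for the aromatic one. Set against the tert-butyl ester, cyclohexylmethyl gives a 1.2-fold lower number from compound 1 to compound 3 (0.09 log units; within the scatter), so a ring on the ester oxygen is not enough by itself to reproduce the strong number of compound 2, and among these three compounds that number goes only with 3-phenylpropyl. Nothing measured here gives a reason for this difference between the two groups.

The change from 3-phenylpropyl to cyclohexylmethyl alters the ring and the length of the chain together, so the compounds shown cannot tell how much of the step belongs to each. A 3-cyclohexylpropyl ester, which keeps the longer chain with the saturated ring, and a benzyl ester, which keeps the aromatic ring on the shorter chain, would separate the two.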